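Oxazolyl Replaces Cyclohexyloxy on the Benzyl Carbamate

This account rests on a few compounds, and the source may have more. Where it says the series, first, only, none or still open, it means among the compounds named here.

Compound 3 `O=C(N[C@H]1CNC1=O)OCc1ccc(OC2CCCCC2)cc1` gives 2070 nM in an assay on HEK293 cells for inhibition of N-acylethanolamine-hydrolyzing acid amidase (Homo sapiens), read by fluorescence, with stated times of 10 min and 50 min (on this read-out higher numbers stand for weaker inhibition and lower numbers for stronger inhibition), the highest number among the three measured compounds. Compound 1 `CCCCc1ccc(COC(=O)N[C@H]2CNC2=O)cc1` gives 23 nM in this assay, and compound 2 `CC(C)(C)c1ccc(COC(=O)N[C@H]2CNC2=O)cc1` gives 310 nM. The steps to compound 3 were a 90-fold higher number from compound 1 to compound 3 (1.95 log units; beyond the scatter) and a 6.7-fold higher number from compound 2 to compound 3 (0.82 log units; beyond the scatter), both beyond the scatter, so the group on this aromatic carbon clearly moves the number. Compound 4 `O=C(N[C@H]1CNC1=O)OCc1ccc(-c2cocn2)cc1` differs from compound 3 by 1,3-oxazol-4-yl in place of cyclohexyloxy on an aromatic carbon. Within the data shown here, no measured step introduces an aromatic heterocycle at this position, so the only guidance is that the three groups already tried span a wide range and that compound 3 sits at the weak end of it. A change in either direction is therefore possible, though there is more room for improvement than for loss. Compound 4 is expected to give about 600 nM in this assay, within 100 nM to 4000 nM, which means an estimated step of a 3.5-fold lower number from compound 3 to compound 4 (0.54 log units; beyond the scatter).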

Compound 4, half-maximal inhibitory concentration: 1880 nM
The estimate for compound 4 lay 3.1-fold (0.50 log units) below the measured number; the measured number falls inside the stated range.
By their numbers in this assay, from the lowest: compound 1; then compound 2; then compounds 4 and 3 (each within the scatter of the next).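

In this assay, the exchange of a saturated six-membered ring held through oxygen for a directly attached five-membered aromatic ring leaves the number where it was, with a 1.1-fold lower number from compound 3 to compound 4 (0.04 log units; within the scatter). At this position, then, 1,3-oxazol-4-yl and cyclohexyloxy cannot be told apart, despite their different ring type, heavy-atom count and hydrogen-bond acceptor count. Both sit on the weak side of tert-butyl and butyl, with a 6.1-fold higher number from compound 2 to compound 4 (0.78 log units; beyond the scatter) and an 82-fold higher number from compound 1 to compound 4 (1.91 log units; beyond the scatter), and nothing available bears on the reason for this.

The compounds shown leave open whether a phenyl or pyridyl ring, or an oxazole joined through another ring atom, would match 1,3-oxazol-4-yl. They also leave open whether a pentyl or hexyl chain would give a lower number than the butyl of compound 1.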